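From tert-butyl to nitro: a single group exchanged

A few compounds are considered here, and "the series" means these few. Any claim that something is new, unique, unknown or untested is made for them only; others in the source may bear on it.

Values in an ADME assay on WI-38 cells (Homo sapiens) for cytotoxicity, read by MTT assay, with a stated time of 72 h; on this read-out lower numbers stand for stronger inhibition and higher numbers for weaker inhibition:
Compound 1 `O=C(CCc1cccc2c1B(O)OC2)Nc1ccc(F)cc1`: 12000 nM
Compound 2 `O=C(CCc1cccc2c1B(O)OC2)Nc1ccc(I)cc1`: 49000 nM
Compound 3 `CC(C)(C)c1ccc(NC(=O)CCc2cccc3c2B(O)OC3)cc1`: 55000 nM

Compound 3 stands at the high end of these numbers, though tert-butyl and iodo cannot be told apart here: a 1.1-fold higher number from compound 2 to compound 3 (0.05 log units; within the scatter). Fluoro stands apart from both, with a 4.1-fold higher number from compound 1 to compound 2 (0.61 log units; beyond the scatter) and a 4.6-fold higher number from compound 1 to compound 3 (0.66 log units; beyond the scatter). Compound 4 `O=C(CCc1cccc2c1B(O)OC2)Nc1ccc([N+](=O)[O-])cc1` carries nitro in place of tert-butyl on an aromatic carbon. Among the measured compounds shown here, no nitro compound has been measured, so these steps are only a rough guide. With compound 3 at 55000 nM and compound 1 at 12000 nM, a modest step toward lower numbers is expected in this assay, though it may stay within the scatter. The expected change is a 2.2-fold lower number from compound 3 to compound 4 (0.34 log units; beyond the scatter). For compound 4 the estimated value is 25000 nM, with an expected range of 9000 nM to 70000 nM.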

Compound 4, half-maximal inhibitory concentration: > 100000 nM
Compound 4 ended at the assay's limit; the forecaster's own chance of this, stated with the estimate: 10%; at least 4.0-fold (0.60 log units) between middle value and limit.
By their numbers in this assay, from the lowest: compound 1; then compounds 2 and 3 (each within the scatter of the next). At a limit, above all of these: compound 4.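

In this assay compound 4 stands at a limit of the assay and not at a number: the limit of > 100000 nM in this assay, at which 1 of the 4 values shown sits. Among the compounds shown here, exchanging one group at this place therefore spans a wider range than the earlier compounds showed, with an at least 8.3-fold higher number from compound 1 to compound 4 (0.92 log units; beyond the scatter) as the step from fluoro to nitro. The floors of the other two steps, an at least 1.8-fold higher number from compound 3 to compound 4 (0.25 log units; that floor lies within the scatter) and an at least 2.0-fold higher number from compound 2 to compound 4 (0.30 log units; that floor lies within the scatter), leave the nitro compound not yet separated from the tert-butyl and iodo compounds. On these data alone, how far beyond the limit compound 4 truly lies remains open. So does whether an amine or a carboxylic acid at this place would sit nearer compound 1 or also reach the limit.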